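Swapping an allyl for a pyrazole on the amide nitrogen

The source may hold more compounds than are shown below. What is called first, only, known or untested is meant among the compounds shown, and "the series" means these compounds.

Compound 2 `C=CCN(Cc1cccs1)C(=O)COc1ccc(C)cc1` has the lowest number of the two measured compounds in an assay on HEK293 cells for agonist activity at transient receptor potential cation channel subfamily M member 8 (Homo sapiens), read by fluorescence and calcium flux, with a stated time of 15 min (a higher number here means that more compound is needed for the effect, a lower number that less compound is needed), giving 20 nM. Among the compounds with values here, its only measured neighbour is compound 1 `Cc1ccc(OCC(=O)N(Cc2cccs2)CC(C)C)cc1`, which gives 900 nM in this assay; the step of a 45-fold lower number from compound 1 to compound 2 (1.65 log units; beyond the scatter) shows that the group on the amide-type nitrogen has a strong say on the read-out. Compound 3 `Cc1ccc(OCC(=O)N(Cc2cccs2)c2c[nH]nc2C)cc1` has not yet been measured. It differs from compound 2 in one place: 3-methyl-1H-pyrazol-4-yl in place of allyl on an amide-type nitrogen. Within the data shown here, no measured step exchanges a chain for an aromatic ring at this nitrogen, so the direction rests on the single step seen, which favoured vinyl over isopropyl in that place. A ring carrying a hydrogen-bond donor is a larger departure from that pattern, and the number for compound 3 is therefore expected to rise, an estimated step of a 15-fold higher number from compound 2 to compound 3 (1.18 log units; beyond the scatter). Compound 3 is estimated at 300 nM, with a plausible range from 40 nM to 3000 nM.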

Compound 3, half-maximal effective concentration: 0.4 nM
For compound 3 the middle estimate is 750-fold (2.88 log units) above the measured one; the measured number lies below the stated range.
By their numbers in this assay, from the lowest: compound 3; then compound 2; then compound 1.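

In this assay the amide-type nitrogen turns out to accept an aromatic ring as well as a chain: 3-methyl-1H-pyrazol-4-yl in place of allyl gives a 50-fold lower number from compound 2 to compound 3 (1.70 log units; beyond the scatter) and, in place of isobutyl, a 2300-fold lower number from compound 1 to compound 3 (3.35 log units; beyond the scatter) at the same nitrogen. The earlier step compared only two small chains, whereas these steps show that a five-membered aromatic ring with a hydrogen-bond donor and a hydrogen-bond acceptor can lower the number further than either chain does. No supporting measurement bears on why the number falls so far. Still open, as far as these compounds go, is which part of the new group counts: the aromatic ring itself, its methyl or its hydrogen-bearing nitrogen. A phenyl ring, an unsubstituted pyrazole or a pyrazole with a methyl on that nitrogen would help separate these.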